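Amide aryl variation: expectation for compound 4

A few compounds are considered here, and "the series" means these few. Any claim that something is new, unique, unknown or untested is made for them only; others in the source may bear on it.

The three measured compounds share the core of compound 1 `COc1ccccc1C(=O)Nc1cccc(-c2oc3cc(-c4ccc(F)cc4)ccc3c(=O)c2O)c1` and differ only in the aryl group on the carbonyl carbon of the amide. In a functional assay on MCF7 cells (Homo sapiens) for antiproliferative activity, read by CCK-8 assay, with a stated time of 72 h (on this read-out lower numbers stand for stronger inhibition and higher numbers for weaker inhibition), compound 1 gives 2100 nM. Compound 2 `O=C(Nc1cccc(-c2oc3cc(-c4ccc(F)cc4)ccc3c(=O)c2O)c1)c1ccc(C(F)(F)F)cc1` gives 32600 nM, and compound 3 `COc1cccc(C(=O)Nc2cccc(-c3oc4cc(-c5ccc(F)cc5)ccc4c(=O)c3O)c2)c1` gives 15300 nM, which is the second highest of the three numbers. The measured steps are a 16-fold higher number from compound 1 to compound 2 (1.19 log units; beyond the scatter), a 7.3-fold higher number from compound 1 to compound 3 (0.86 log units; beyond the scatter) and a 2.1-fold lower number from compound 2 to compound 3 (0.33 log units; beyond the scatter).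

Compound 4 `O=C(Nc1cccc(-c2oc3cc(-c4ccc(F)cc4)ccc3c(=O)c2O)c1)c1ccc([N+](=O)[O-])cc1` is not yet measured. The change from compound 3 is 4-nitrophenyl in place of 3-methoxyphenyl on a carbonyl carbon. The closest analogy among the measured steps is the reverse of a 2.1-fold lower number from compound 2 to compound 3 (0.33 log units; beyond the scatter), where 3-methoxyphenyl replaced 4-(trifluoromethyl)phenyl; the much larger a 16-fold higher number from compound 1 to compound 2 (1.19 log units; beyond the scatter) concerns 2-methoxyphenyl and is less direct. A modest step toward a higher number, close to the size of that reverse step, is therefore expected in this assay, namely a 2.0-fold higher number from compound 3 to compound 4 (0.29 log units; within the scatter). Compound 4 is estimated at 30000 nM, with a range from 10000 nM to 90000 nM.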

Compound 4, half-maximal inhibitory concentration: 3970 nM
Compound 4: middle estimate off by 7.6-fold (0.88 log units), on the high side, outside the stated range (below it).
By their numbers in this assay, from the lowest: compounds 1 and 4 (each within the scatter of the next); then compound 3; then compound 2.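

In this assay the 4-nitrophenyl group gives a 3.9-fold lower number from compound 3 to compound 4 (0.59 log units; beyond the scatter) and, on the same aromatic carbon that carries trifluoromethyl in compound 2, nitro gives an 8.2-fold lower number from compound 2 to compound 4 (0.91 log units; beyond the scatter) so these two groups are not interchangeable at this position. The earlier compounds shown here left 2-methoxyphenyl alone at the low end of the series, but a 1.9-fold higher number from compound 1 to compound 4 (0.28 log units; within the scatter) now places a second aryl group level with it, and one that is substituted at a different ring position. Nothing at hand bears on why nitro and trifluoromethyl read so differently here.

As far as these compounds go, how an amine, a carboxylic acid or a nitrile in place of nitro on that aromatic carbon would read stays open. Also open, from the compounds shown here alone, is whether the 4-nitrophenyl amide keeps this level when the shared core is changed elsewhere.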